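This account rests on a few compounds, and the source may have more. Where it says the series, first, only, none or still open, it means among the compounds named here.

Measured so far:
compound 1 `O[C@@H](CCc1ccc(F)cc1)C[C@@H](O)c1cc(-c2ccccc2)on1`: > 100000 nM
compound 2 `COc1ccc(CC[C@H](O)C[C@@H](O)c2cc(-c3ccccc3)on2)cc1`: > 100000 nM
compound 3 `COc1cccc(CC[C@H](O)C[C@@H](O)c2cc(-c3ccccc3)on2)c1`: > 100000 nM

All three entries come from an ADME assay on HepG2 cells (Homo sapiens) for cytotoxicity, read by MTT assay, with a stated time of 24 h; a lower number here means a stronger inhibitor, a higher number a weaker inhibitor. In this assay compound 1 gives > 100000 nM, which is a limit and not a number. The same holds for the other two compounds, as the limit of > 100000 nM in this assay, at which 3 of the 3 values shown sit, shows.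

Compound 4 `O[C@@H](CCc1ccc(F)cc1)C[C@H](O)c1cc(-c2ccccc2)on1` has not yet been measured. It differs from compound 1 as follows: the two compounds have the same atoms and bonds and differ only in configuration as drawn: 1 of 2 stereo elements differ; a stereocentre at a saturated chain carbon is drawn R in compound 1 and S in compound 4.

Three measured steps are available: a step that the two limits leave unreadable from compound 1 to compound 2, a step that the two limits leave unreadable from compound 1 to compound 3 and a step that the two limits leave unreadable from compound 2 to compound 3. Their sizes cannot be read, and none of them alters a configuration, so they bear on this change only indirectly. Going by the values given here, with no measured step to suggest a shift in this assay, no direction can be given, and a step beyond the scatter is not expected. The expected result is a further limit reading. As a number, the expected step is a step that the limit leaves unreadable from compound 1 to compound 4. Compound 4 is estimated at 120000 nM, with an expected range from 50000 nM to 300000 nM.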

Compound 4, half-maximal inhibitory concentration: > 100000 nM
Compound 4 gave a limit, no number (the forecaster's own chance of this, stated with the estimate: 85%); the middle value is on the limit's open side.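

In this assay compound 4 gives > 100000 nM, which is a limit and not a number. Going by these compounds alone, compound 1 also gives a limit, so no step between compound 1 and compound 4 can be read. The compounds shown leave open whether the configuration at that stereocentre has any effect in this assay.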